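From Butylpiperazine to Methylpiperazine in a Cytotoxicity Series

The compounds below may be only part of what the source reports. "The series", "measured", "known", "first", "only" and "open" are said of these compounds alone.

Of the compounds shown here, two sharing one core have been measured in a functional assay on A-375 cells (Homo sapiens) for cytotoxicity, read by MTT assay, with a stated time of 72 h (a higher number here means a weaker inhibitor, a lower number a stronger inhibitor), so far. Compound 1 (`CCCCN1CCN(CCCCn2c3c(c4ccccc42)C(=O)c2c[n+]([O-])c4ccccc4c2C3=O)CC1`) gives 2150 nM in this test and holds the higher of the two numbers. Compound 2 (`CC1(C)OC[C@@H](Cn2cc(Cn3c4c(c5ccccc53)C(=O)c3c[n+]([O-])c5ccccc5c3C4=O)nn2)O1`) carries a different side chain and gives 450 nM as its value, a gap beyond the usual scatter that leaves compound 1 as the weaker inhibitor of the pair.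

Compound 3 (`CN1CCN(CCCCCn2c3c(c4ccccc42)C(=O)c2c[n+]([O-])c4ccccc4c2C3=O)CC1`) has not yet been measured. It departs from compound 1 by one change, (4-methylpiperazin-1-yl)methyl in place of 4-butylpiperazin-1-yl on a saturated chain carbon, four bonds along the chain from an aromatic nitrogen on a saturated chain carbon, four bonds along the chain from an aromatic nitrogen. The same difference can be read as 2-(4-butylpiperazin-1-yl)ethyl to 3-(4-methylpiperazin-1-yl)propyl.

Among the measured compounds shown here, no measured pair isolates a change of this kind, so the data offer no direct guide to its size. With the piperazine ring kept, no shift beyond the scatter is expected in this assay at this stage. The expected step of a 1.3-fold lower number from compound 1 to compound 3 (0.13 log units; within the scatter) is therefore small and has no firm direction. For compound 3 the estimated value is 1600 nM with an expected range of 550 nM to 4500 nM in this test.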

Compound 3, half-maximal inhibitory concentration: 1710 nM
Beside the measured number, compound 3's estimate is 1.1-fold (0.03 log units) below it; the range from low to high includes it.
By their numbers in this assay, from the lowest: compound 2; then compounds 3 and 1 (each within the scatter of the next).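

Among the compounds shown here, exchanging 4-butylpiperazin-1-yl for (4-methylpiperazin-1-yl)methyl on a saturated chain carbon, four bonds along the chain from an aromatic nitrogen, gives the first step that can be read at a single place: in this assay it comes to a 1.3-fold lower number from compound 1 to compound 3 (0.10 log units; within the scatter), so compound 1 and compound 3 cannot be told apart in this test. The same difference reads as 2-(4-butylpiperazin-1-yl)ethyl to 3-(4-methylpiperazin-1-yl)propyl, which means that the group on the piperazine and the chain carrying the ring differ together, and this pair shows that the combined exchange leaves the number within the scatter. No measurement is available that would explain this result.

The pair cannot show whether the two parts of the exchange each have little effect or whether they offset one another, and 3-(4-butylpiperazin-1-yl)propyl at this place would separate them. The compounds shown also leave open how a morpholine or a piperidine in place of the piperazine, or a free piperazine amine at the end of the chain, would read in this test.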